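The source may hold more compounds than are shown below. What is called first, only, known or untested is meant among the compounds shown, and "the series" means these compounds.

Measured so far:
- compound 1, `CC(=O)Nc1ccc(S(=O)(=O)Oc2ccccc2I)cc1` — 27000 nM
- compound 2, `CCC(=O)Nc1ccc(S(=O)(=O)Oc2ccccc2I)cc1` — 8100 nM
- compound 3, `CCCCCC(=O)Nc1ccc(S(=O)(=O)Oc2ccccc2I)cc1` — 10000 nM

All three share one core and differ only in the chain attached to the carbonyl of the amide. In a functional assay on MCF7 cells (Homo sapiens) for antiproliferative activity, read by sulforhodamine B assay, with a stated time of 48 h (a higher number here means a weaker inhibitor, a lower number a stronger inhibitor), compound 1 gives 27000 nM, compound 2 gives 8100 nM and compound 3 gives 10000 nM. On these three numbers compound 3 stands second highest: its nearest neighbour is compound 2, within the scatter, and its furthest is compound 1.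

Compound 4, `CC(C)(C)C(=O)Nc1ccc(S(=O)(=O)Oc2ccccc2I)cc1`, is the next step: tert-butyl in place of pentyl on a carbonyl carbon. Among the measured compounds shown here, three steps bear on it. a 3.3-fold lower number from compound 1 to compound 2 (0.52 log units; beyond the scatter) and a 2.7-fold lower number from compound 1 to compound 3 (0.43 log units; beyond the scatter) show that lengthening the chain from the smallest case brought a modest gain, while a 1.2-fold higher number from compound 2 to compound 3 (0.09 log units; within the scatter) shows that further lengthening changed nothing beyond the scatter. For the measured compounds named here, no measured step tests a branched chain, so a branched group of four carbons has no direct precedent here. Since compound 4 keeps a chain of similar size, the expected outcome in this assay is no change beyond the scatter, as a 1.1-fold lower number from compound 3 to compound 4 (0.05 log units; within the scatter). Compound 4 is therefore estimated at 9000 nM, within a range of 4000 nM to 25000 nM.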

Compound 4, half-maximal inhibitory concentration: 6600 nM
Compound 4: the middle estimate sits 1.4-fold (0.13 log units) above what was measured; the measured number falls inside the stated range.
By their numbers in this assay, from the lowest: compounds 4, 2 and 3 (each within the scatter of the next); then compound 1.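

In this assay a branched group on this carbonyl carbon can't be told apart from the straight chains: tert-butyl in place of pentyl (a 1.5-fold lower number from compound 3 to compound 4 (0.18 log units; within the scatter)) and tert-butyl in place of ethyl (a 1.2-fold lower number from compound 2 to compound 4 (0.09 log units; within the scatter)) both stay within the scatter. Tert-butyl in place of methyl (a 4.1-fold lower number from compound 1 to compound 4 (0.61 log units; beyond the scatter)) lies beyond the scatter, so compounds 2, 3 and 4 now form one cluster of numbers, branched or not, with compound 1 standing apart from them as the weakest of the four. No measured evidence here explains why these three groups give such similar numbers.

On these data alone, it remains open whether a chain longer than pentyl, or a ring such as cyclohexyl or phenyl on this carbonyl carbon, would stay in that cluster. A chain ending in an amine or a carboxylic acid is equally untested in the compounds shown.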